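Swapping a tert-Butyl Carbamate for an Oxolanyl Carbamate

This account rests on a few compounds, and the source may have more. Where it says the series, first, only, none or still open, it means among the compounds named here.

Measured so far:
Compound 1 `Cc1cc(NC(=O)C2CCCO2)nn1Cc1cc(Cl)ccc1OCc1ccccc1`: 39.8 nM
Compound 2 `Cc1cc(NC(=O)OC(C)(C)C)nn1Cc1cc(Cl)ccc1OCc1ccccc1`: 25.1 nM

Both compounds share one core and differ only in the group attached to the carbonyl carbon of the side chain. In an assay on CHO-K1 cells for displacement of a labelled ligand from prostaglandin E2 receptor EP1 subtype (Homo sapiens) (on this read-out higher numbers stand for weaker inhibition and lower numbers for stronger inhibition), compound 2 gives 25.1 nM and compound 1 gives 39.8 nM; the step of a 1.6-fold lower number from compound 1 to compound 2 (0.20 log units; within the scatter) is the only one measured, and it falls within the scatter, so the two cannot be told apart on this read-out.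

Compound 3 `Cc1cc(NC(=O)O[C@H]2CCOC2)nn1Cc1cc(Cl)ccc1OCc1ccccc1` is the next step from compound 2: oxolan-3-yl in place of tert-butyl on an oxygen next to a carbonyl group. Within the data shown here, the one measured step does not copy this change, since it replaced an oxolan-2-yl on the carbonyl carbon with a tert-butoxy rather than exchanging one oxygen-bound group for another. What it does show is that a ring carrying an oxygen in this region and a tert-butyl group gave numbers within the scatter of each other. By that reasoning, no step beyond the scatter is expected from compound 2 to compound 3, a 1.4-fold higher number from compound 2 to compound 3 (0.14 log units; within the scatter). Compound 3 is therefore estimated at 35 nM in this assay, with a range from 12 nM to 100 nM.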

Compound 3, half-maximal inhibitory concentration: 79.4 nM
Compound 3: the middle estimate sits 2.3-fold (0.36 log units) below what was measured; the range from low to high includes it.
By their numbers in this assay, from the lowest: compounds 2, 1 and 3 (each within the scatter of the next, the first and the last beyond it).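

In this assay, exchanging tert-butyl for oxolan-3-yl on an oxygen gives a 3.2-fold higher number from compound 2 to compound 3 (0.50 log units; beyond the scatter), a modest step but the only one in this small set that lies beyond the scatter. This shows that the group on this oxygen can shift the read-out measurably, which the earlier pair of compounds could not show. The other new step, a 2.0-fold higher number from compound 1 to compound 3 (0.30 log units; within the scatter), stays within the scatter, so compound 1 and compound 3 cannot be told apart, just as compound 1 and compound 2 could not, and only the two carbamates, compound 2 and compound 3, are separated. Nothing at hand gives a reason for this difference.

The compounds shown cannot separate the contributions of the ring, its oxygen and its defined stereocentre, since all three enter together in compound 3. From the compounds shown here alone, a plain cyclopentyl ring, the mirror-image form of oxolan-3-yl, or a pyrrolidin-3-yl ring carrying an amine nitrogen on the same oxygen would each bear on that question, and the effect of any of them remains open.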